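One Stereocentre Flipped: From Compound 1 to Compound 3

The source may report more compounds than this note shows. Statements on the series, on what has been measured and on what is new or still open speak of the compounds shown alone.

Compound 1 `CC(=O)OC[C@H]1O[C@@H](Oc2nc(-c3cccs3)cc(-c3ccc(Cl)cc3)c2C#N)[C@H](OC(C)=O)[C@@H](OC(C)=O)[C@H]1OC(C)=O` gives 5% in a functional assay on MCF7 cells (Homo sapiens) for inhibition, read by MTT assay, with a stated time of 48 h, tested at 50 ug/mL; a higher number here means a stronger effect of the compound at the concentration tested, a lower number a weaker effect. Its nearest companion, compound 2 `N#Cc1c(-c2ccc(Cl)cc2)cc(-c2cccs2)nc1O[C@@H]1O[C@H](CO)[C@@H](O)[C@H]1O`, gives 0% in this assay, a value within the scatter of compound 1, so neither can be called the stronger. Compound 3 `CC(=O)OC[C@H]1O[C@@H](Oc2nc(-c3cccs3)cc(-c3ccc(Cl)cc3)c2C#N)[C@H](OC(C)=O)[C@@H](OC(C)=O)[C@@H]1OC(C)=O` awaits measurement. Relative to compound 1, (the two compounds have the same atoms and bonds and differ only in configuration as drawn: 1 of 5 stereo elements differ; a stereocentre at a saturated ring carbon is drawn S in compound 1 and R in compound 3). Among the compounds with values here, no pair of measured compounds differs in a single place, so no measured step guides the change. The step of no change at the digits printed from compound 1 to compound 3 (within the scatter) in this assay is expected to stay within the scatter, with no direction favoured. Compound 3 is therefore estimated at 5%, with a range of 0% to 15%.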

Compound 3, a percentage reported as inhibition, at one concentration (the size of the read-out at that concentration, not a potency): 5%
Compound 3: middle estimate and measured number agree at the digits printed; measured number inside the range.
By their numbers in this assay, from the lowest: compounds 2, 1 and 3 (each within the scatter of the next).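

Inverting this one saturated ring carbon gives no change at the digits printed from compound 1 to compound 3 (within the scatter) in this assay, the only step shown that isolates a single place. The comparison involves nothing else: the fact that compounds 1 and 3 differ only in the configuration as drawn. At this one concentration, then, the drawn configuration at this carbon does not separate the two compounds, although the read-out is not a potency.

The compounds shown leave open whether the other stereocentres would behave in the same way. They also leave open whether a different group at this carbon, such as an amine, would change the reading.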